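The source may report more compounds than this note shows. Statements on the series, on what has been measured and on what is new or still open speak of the compounds shown alone.

Working notes on a set of arylidene compounds built on one shared core. Compound 1 `O=C1NC(=S)/C(=C/c2ccc(Cl)cc2)S1` carries a single chloro group; in a functional assay on NCI-H292 cells (Homo sapiens) for cytotoxicity, read by MTT assay, with a stated time of 72 h, tested at 1.25 ug/mL (a higher number here means more inhibition of growth at the concentration tested, a lower number less inhibition of growth), compound 1 gives 10%. Compound 2 `O=C1NC(=S)/C(=C/c2cc(Cl)cc(Cl)c2Cl)S1` carries three chloro groups, and in this assay compound 2 gives 14.2%. Compound 3 `O=C1NC(=S)/C(=C/c2cccc(Cl)c2)S1` again carries a single chloro group, and in this assay compound 3 gives 3.35%, the lowest of the three numbers. The gap between compound 3 and compound 1 lies within the usual scatter of this read-out, so no order between those two is asserted; the gap between compound 3 and compound 2 lies beyond it.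

Compound 4 `O=C1NC(=S)/C(=C/c2cccc(F)c2)S1` has not yet been measured. It differs from compound 3 in one place: fluoro in place of chloro on an aromatic carbon. Among the measured compounds shown here, no measured pair in the set makes this same exchange, so the numbers at hand show nothing about what a fluoro-for-chloro swap does in this assay. Given that the three measured values sit in a narrow band and that one heavy atom is exchanged for one heavy atom, the step from compound 3 to compound 4 is expected to be a number 1.7 percentage points higher from compound 3 to compound 4 (within the scatter), in no particular direction and not beyond the scatter. Compound 4 is therefore estimated to give about 5% in this assay, somewhere between 0% and 15%.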

Compound 4, percent growth inhibition at one concentration: 2.1%
Beside the measured number, compound 4's estimate is 2.9 percentage points above it; the measured number falls inside the stated range.
By their numbers in this assay, from the lowest: compounds 4, 3, 1 and 2 (each within the scatter of the next, the first and the last beyond it).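

Fluoro in place of chloro on an aromatic carbon, meta to a group of 8 heavy atoms, gives a number 1.3 percentage points lower from compound 3 to compound 4 (within the scatter) in this assay, and this is the first direct reading of this exchange in the series, since no earlier pair of compounds differed in this way. At this position, the read-out therefore does not separate the two halogens, and no order between them can be stated from this single pair. The result covers this one exchange at this one place on the ring and cannot be carried over to the other chloro positions in the set, while no accompanying measurement bears on what lies behind it.

On these data alone, it remains open whether a group of another kind at this aromatic carbon, such as an amine, a carboxylic acid, a methoxy group or a longer alkyl chain, would move the growth inhibition beyond the scatter. As far as these compounds go, it also remains open whether the same fluoro-for-chloro exchange would read alike at another carbon of the ring or on the trichloro pattern of compound 2.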